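Swapping the Dichlorophenoxy Group for a Fluorophenoxy One

A few compounds are considered here, and "the series" means these few. Any claim that something is new, unique, unknown or untested is made for them only; others in the source may bear on it.

Within the data shown here, compound 1 `Nc1cc(N)c2nc(-c3ccccc3)c(Oc3ccc(Cl)c(Cl)c3)nc2c1` is one of two compounds measured in a functional assay on M14 cells (Homo sapiens) for inhibition, read by sulforhodamine B assay, with a stated time of 48 h; a higher number here means a weaker inhibitor of growth, a lower number a stronger inhibitor of growth. In this assay compound 1 gives 14100 nM, the lower of the two numbers. Compound 2 `CCOC(=O)[C@H](CCC(=O)O)NC(=O)c1ccc(Oc2nc3cc(N)cc(N)c3nc2-c2ccccc2)cc1` gives 39800 nM, a gap beyond the usual scatter. Compound 3 `Nc1cc(N)c2nc(-c3ccccc3)c(Oc3ccc(F)cc3)nc2c1` is not yet measured and differs from compound 1 in one place: 4-fluorophenyl in place of 3,4-dichlorophenyl on an oxygen on an aromatic ring. Among the measured compounds shown here, no measured pair shows this same change, so the size of the step is uncertain. The expected step is a 1.6-fold higher number from compound 1 to compound 3 (0.19 log units; within the scatter), modest and toward a higher number. For compound 3 the estimate in this assay is 22000 nM, with a likely range from 7000 nM to 70000 nM.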

Compound 3, concentration for 50% growth inhibition: 17000 nM
Compound 3: middle estimate off by 1.3-fold (0.11 log units), on the high side, within the range that was stated.
By their numbers in this assay, from the lowest: compounds 1 and 3 (each within the scatter of the next); then compound 2.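

Going from 3,4-dichlorophenyl to 4-fluorophenyl on this oxygen in this assay gives a 1.2-fold higher number from compound 1 to compound 3 (0.08 log units; within the scatter). This one-place comparison shows that the two halogen-bearing rings cannot be told apart here, even though one chlorine is lost and the other is replaced by fluorine. No accompanying measurement bears on this result.

Going by these compounds, it remains open what a nitrile or a methoxy group on this phenyl ring would give. On these data alone, it is also open whether a longer chain on the oxygen would read the same.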